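The source may hold more compounds than are shown below. What is called first, only, known or untested is meant among the compounds shown, and "the series" means these compounds.

Notes on the series, read in an ADME assay on MT4 cells (Homo sapiens) for cytotoxicity, read by MTT assay, with a stated time of 5 days; on this read-out higher numbers stand for lower toxicity in this test and lower numbers for higher toxicity in this test. Compound 1 `Cc1cc(C)cc(S(=O)(=O)c2c(C(=O)N[C@H]3CCNC3)[nH]c3ccc(Cl)cc23)c1` gives 10000 nM. Compound 2 `Cc1cc(C)cc(S(=O)(=O)c2c(C(=O)NC3CN(S(C)(=O)=O)C3)[nH]c3ccc(Cl)cc23)c1` gives > 252000 nM, which is a limit of the assay and not a number. Compound 3 `Cc1cc(C)cc(S(=O)(=O)c2c(C(=O)NS(=O)(=O)c3ccc(F)cc3F)[nH]c3ccc(Cl)cc23)c1` gives 121000 nM, the higher of the two actual numbers. Going by the values given here, it stands clear of the only other actual number, with a 12-fold higher number from compound 1 to compound 3 (1.08 log units; beyond the scatter), while an at least 2.0-fold lower number from compound 2 to compound 3 (0.31 log units; beyond the scatter) is set against a limit.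

Compound 4 `Cc1cc(C)cc(S(=O)(=O)c2c(C(=O)NS(=O)(=O)c3ccccc3)[nH]c3ccc(Cl)cc23)c1` carries one change from compound 3: phenyl in place of 2,4-difluorophenyl on a sulfonyl sulfur. The measured steps bear on this only indirectly. Each one swaps the whole group on the amide-type nitrogen: an at least 25-fold higher number from compound 1 to compound 2 (1.40 log units; beyond the scatter) and a 12-fold higher number from compound 1 to compound 3 (1.08 log units; beyond the scatter) are large, and an at least 2.0-fold lower number from compound 2 to compound 3 (0.31 log units; beyond the scatter) is at least modest. None of them removes fluorine from a group that otherwise stays the same, so the series holds no direct measure of this change. Compound 4 keeps the sulfonyl link on the amide-type nitrogen and lacks the pyrrolidin-3-yl of compound 1, so no step beyond the scatter is expected, and no direction is favoured. The expected result is a 1.1-fold lower number from compound 3 to compound 4 (0.04 log units; within the scatter). Compound 4 is estimated at 110000 nM, with an expected range of 45000 nM to 250000 nM.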

Compound 4, half-maximal cytotoxic concentration: 167000 nM
Compound 4: the middle estimate sits 1.5-fold (0.18 log units) below what was measured, within the range that was stated.
By their numbers in this assay, from the lowest: compound 1; then compounds 3 and 4 (each within the scatter of the next). At a limit, above all of these: compound 2.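

In this assay, the series now has its first direct read on the group on the sulfonyl sulfur: a 1.4-fold higher number from compound 3 to compound 4 (0.14 log units; within the scatter), so compound 3 and compound 4 cannot be told apart, with phenyl in place of 2,4-difluorophenyl. The large step of a 17-fold higher number from compound 1 to compound 4 (1.22 log units; beyond the scatter) stands alongside a 12-fold higher number from compound 1 to compound 3 (1.08 log units; beyond the scatter), so in this pair of sulfonyl compounds the distance from the pyrrolidin-3-yl amide does not rest on the fluorine atoms. The step of an at least 1.5-fold lower number from compound 2 to compound 4 (0.17 log units; that floor lies within the scatter) is set against a limit of the assay and not a number, and it fixes no order: the limit of > 252000 nM in this assay, at which 1 of the 4 values shown sits.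

Still open, as far as these compounds go, is whether other groups on the phenyl ring of the phenylsulfonyl group, such as an amine, a carboxylic acid or a methoxy group, would stay with compound 3 and compound 4 or move away from them. No cause for the gap to compound 1 can be drawn from these compounds, as each step to it replaces the whole group on the amide-type nitrogen.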